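Phenyl in place of methoxy at the edge of measurement

The source may hold more compounds than are shown below. What is called first, only, known or untested is meant among the compounds shown, and "the series" means these compounds.

Compound 2 `COc1ccccc1CNc1nc2c(N)ncnc2n1[C@@H]1O[C@H](CO)[C@@H](O)[C@H]1O` is characterised in an assay on COS-7 cells for inhibition of sodium/nucleoside cotransporter 2 (Homo sapiens), read by scintillation counting, in the presence of a further agent that is not named here (a lower number here means a stronger inhibitor, a higher number a weaker inhibitor), where compound 2 gives > 100000 nM, which is a limit of the assay and not a number. Its nearest measured neighbour, compound 1 `Cc1ccccc1CNc1nc2c(N)ncnc2n1[C@@H]1O[C@H](CO)[C@@H](O)[C@H]1O`, carries a methyl where compound 2 carries a methoxy, and compound 1 gives 65000 nM in this assay. The step of an at least 1.5-fold higher number from compound 1 to compound 2 (0.18 log units; that floor lies within the scatter) is only a floor because compound 2 sits at the limit of > 100000 nM in this assay, at which 1 of the 2 values shown sits. Compound 3 `Nc1ncnc2c1nc(NCc1ccccc1-c1ccccc1)n2[C@@H]1O[C@H](CO)[C@@H](O)[C@H]1O` is built from compound 2 by phenyl in place of methoxy on an aromatic carbon. Among the measured compounds shown here, only the step from compound 1 to compound 2 bears on this change, and it is at its floor within the scatter, so no step beyond the scatter is expected in this assay, in either direction. Compound 3 is therefore expected to give about 100000 nM, in an estimated range from 30000 nM to 300000 nM. The expected step of a number no higher from compound 2 to compound 3 (the limit leaves the size open) lies within the scatter, and a limit rather than a number is quite possible.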

Compound 3, half-maximal inhibitory concentration: > 100000 nM
Compound 3: only a limit was reported; the forecaster's own chance of this, stated with the estimate: 50%; the middle value sits exactly at the limit.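

With phenyl on this aromatic carbon, ortho to a large group, compound 3 joins compound 2 in giving a limit and not a number in this assay: the limit of > 100000 nM in this assay, at which 2 of the 3 values shown sit.

The step between compound 2 and compound 3 therefore cannot be read, and methoxy and phenyl cannot be ranked here. Phenyl in place of methyl gives an at least 1.5-fold higher number from compound 1 to compound 3 (0.18 log units; that floor lies within the scatter), so the only comparison that can be read at this position is a floor, and it shows no gain over methyl.

On these data alone, how far compound 2 and compound 3 lie past the limit stays open. So does whether a hydroxyl, an amine or a chlorine atom on this aromatic carbon would give a number clearly lower than that of compound 1.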